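A few compounds are considered here, and "the series" means these few. Any claim that something is new, unique, unknown or untested is made for them only; others in the source may bear on it.

In a functional assay on U2OS cells (Homo sapiens) for cytotoxicity, read by MTT assay, with a stated time of 48 h (a lower number here means a stronger inhibitor, a higher number a weaker inhibitor), compound 1 `Fc1cccc(-c2nc(Nc3ccccc3)c3ccccc3n2)c1` gives > 50000 nM, which is a limit of the assay and not a number. Compound 2 `Fc1cccc(-c2nc(Nc3cccc(Cl)c3)c3cc(F)ccc3n2)c1` also gives only a limit in this assay, namely > 50000 nM. Compound 3 `Fc1cccc(-c2nc(Nc3ccccc3Cl)c3cc(F)ccc3n2)c1` likewise gives only a limit in this assay, namely > 50000 nM. The one step among these three that changes a single place, a step that the two limits leave unreadable from compound 2 to compound 3, is unreadable because of the limit of > 50000 nM in this assay, at which 3 of the 3 values shown sit. Compound 3 therefore stands at the limit shared by every measured compound, with no number of its own to anchor it.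

Compound 4 `Oc1cccc(Nc2nc(-c3cccc(F)c3)nc3ccc(F)cc23)c1` differs from compound 3 in one place: 3-hydroxyphenyl in place of 2-chlorophenyl on a nitrogen on an aromatic ring. Within the data shown here, no measured step concerns a hydroxyphenyl group, and the only single-place step available, a step that the two limits leave unreadable from compound 2 to compound 3, has no readable size, so the data give no direction for this assay here. Among the measured compounds shown here, the three shared limits leave open both a change hidden by them and no change at all, and the expectation can only rest on the fact that no measured compound has yet produced a number. Compound 4 is expected to give 50000 nM in this assay, within 15000 nM to 150000 nM, most probably as another limit rather than a number. The step is estimated as a number no higher from compound 3 to compound 4 (the limit leaves the size open).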

Compound 4, half-maximal inhibitory concentration: 33300 nM
Estimate against measurement, compound 4: 1.5-fold (0.18 log units) above, within the range that was stated.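

In this assay compound 4, with its (3-hydroxyphenyl)amino group, gives the first actual number among the compounds shown, 33300 nM, so a change at this place, on a nitrogen on an aromatic ring, can bring a reading inside the range of the assay. Exchanging the whole ring gives an at least 1.5-fold lower number from compound 3 to compound 4 (0.17 log units; that floor lies within the scatter), and hydroxy in place of chloro on an aromatic carbon, the narrower change, gives an at least 1.5-fold lower number from compound 2 to compound 4 (0.17 log units; that floor lies within the scatter); each of these two steps is only a floor, and neither floor by itself shows a change beyond the scatter. The true size of both steps stays unknown because their starting points are not numbers: the limit of > 50000 nM in this assay, at which 3 of the 4 values shown sit.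

What the compounds shown leave open is whether the reading depends on the hydroxy group alone, since a single number cannot separate that group from the rest of the 3-hydroxyphenyl arrangement, and 2-hydroxyphenyl does not appear among them. They also do not tell how a methoxy group, an amine or a carboxylic acid in place of the hydroxy on that aromatic carbon would read in this assay.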